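This account rests on a few compounds, and the source may have more. Where it says the series, first, only, none or still open, it means among the compounds named here.

Measured in a physicochemical assay for solubility, measured as kinetic solubility; on this read-out higher numbers stand for higher solubility and lower numbers for lower solubility:
- compound 1 `CCC/N=C1\S/C(=C\c2ccc(O)c(C(F)(F)F)c2)C(=O)N1c1ccccc1C`: 14000 nM
- compound 2 `COCC/N=C1\S/C(=C\c2ccc(O)c(Cl)c2)C(=O)N1c1ccccc1C`: 110000 nM

Compound 2, at 110000 nM, stands highest of these two, and the gap down to compound 1 lies beyond the scatter. Compound 3 `CCC/N=C1\S/C(=C\c2ccc(O)c(Cl)c2)C(=O)N1c1ccccc1C` differs from compound 2 in one place: methyl in place of methoxy on a saturated chain carbon, two bonds along the chain from a double-bonded nitrogen. Compound 1 also carries the propyl chain and gives 14000 nM, but it differs from compound 2 in a second place too, so it offers only a loose guide. A downward move is expected, with the estimated step of a 2.8-fold lower number from compound 2 to compound 3 (0.44 log units; beyond the scatter) modest but beyond the scatter. For compound 3 the estimated value is 40000 nM, with a range of 15000 nM to 100000 nM.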

Compound 3, solubility: 79000 nM
Compound 3: the middle estimate sits 2.0-fold (0.30 log units) below what was measured; the measured number falls inside the stated range.
By their numbers in this assay, from the lowest: compound 1; then compounds 3 and 2 (each within the scatter of the next).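

In this assay, putting propyl in place of 2-methoxyethyl gives a 1.4-fold lower number from compound 2 to compound 3 (0.14 log units; within the scatter), so with chloro on the aromatic carbon, this chain change does not separate the two compounds. The clear step lies at the other place, where chloro in place of trifluoromethyl gives a 5.6-fold higher number from compound 1 to compound 3 (0.75 log units; beyond the scatter), a difference the chain change does not match. Nothing measured here explains either result. Still open, as far as these compounds go, is whether methoxy would count for as little alongside trifluoromethyl. Also open, from the compounds shown here alone, is how an amine, a carboxylic acid or a longer chain would read at this position.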